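The compounds below may be only part of what the source reports. "The series", "measured", "known", "first", "only" and "open" are said of these compounds alone.

Measured compounds in a functional assay on U-87MG ATCC cells (Homo sapiens) for cytotoxicity, read by MTT assay, with a stated time of 72 h; a lower number here means a stronger inhibitor, a higher number a weaker inhibitor:
- compound 1 `CN(C)CCn1cnnc1-c1cc(Oc2ccc(NC(=O)N/N=C/c3ccccc3O[N+](=O)[O-])cc2F)ccn1`: 7150 nM
- compound 2 `CN(C)CCn1cnnc1-c1cc(Oc2ccc(NC(=O)N/N=C/c3cccc(Cl)c3Cl)cc2F)ccn1`: 13200 nM
- compound 3 `CN(C)CCn1cnnc1-c1cc(Oc2ccc(NC(=O)N/N=C/c3cccc(Br)c3)cc2F)ccn1`: 830 nM

Compound 3 gives the lowest number of the three in this assay. Its nearest neighbour is compound 1, and the step of an 8.6-fold lower number from compound 1 to compound 3 (0.94 log units; beyond the scatter) lies beyond the scatter; the step of a 16-fold lower number from compound 2 to compound 3 (1.20 log units; beyond the scatter) is larger still. Compound 2 and compound 1 sit close together, the step of a 1.8-fold higher number from compound 1 to compound 2 (0.27 log units; within the scatter) staying within the scatter.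

Compound 4 `CN(C)CCn1cnnc1-c1cc(Oc2ccc(NC(=O)N/N=C/c3ccc(O)cc3O)cc2F)ccn1` has not been measured. It differs from compound 3 only at the aryl group on the carbon with a double bond to nitrogen: 2,4-dihydroxyphenyl in place of 3-bromophenyl on a carbon with a double bond to nitrogen.

Both measured steps at this same position bear on the change. Each replaced a differently substituted phenyl with 3-bromophenyl and lowered the number clearly. Compound 4 moves away from 3-bromophenyl, so the expectation is a higher number in this assay, of a size comparable to those steps, though the direction of a dihydroxy substitution is not directly covered by compound 1 or compound 2. The expected step is a 6.0-fold higher number from compound 3 to compound 4 (0.78 log units; beyond the scatter). Compound 4 is estimated at 5000 nM, with a range of 1500 nM to 16000 nM.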

Compound 4, half-maximal inhibitory concentration: 15400 nM
Estimate against measurement, compound 4: 3.1-fold (0.49 log units) below; measured number inside the range.
By their numbers in this assay, from the lowest: compound 3; then compounds 1, 2 and 4 (each within the scatter of the next, the first and the last beyond it).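

In this assay, compound 3 now stands apart from three differently substituted phenyl groups, with a 19-fold higher number from compound 3 to compound 4 (1.27 log units; beyond the scatter) extending the evidence at this position to 2,4-dihydroxyphenyl. For the compounds shown here, the three groups other than 3-bromophenyl are much less separated from one another: a 1.2-fold higher number from compound 2 to compound 4 (0.07 log units; within the scatter) stays within the scatter, whereas a 2.2-fold higher number from compound 1 to compound 4 (0.33 log units; beyond the scatter) is only a modest change, so the series so far has one clear outlier at the low end rather than a graded order. No measurement at hand explains this difference.

On these data alone, it remains open whether the bromine itself matters, or whether chlorine, a methoxy group or a hydrogen in its place would keep the number near that of compound 3. Also open, as far as these compounds go, is how a single hydroxyl or an amine on the phenyl ring would compare with 2,4-dihydroxyphenyl.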